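This account rests on a few compounds, and the source may have more. Where it says the series, first, only, none or still open, it means among the compounds named here.

Compound 1 `CCO/C(O)=C1\C(COCCn2cc(N)n(C)c2=O)=NC(C)=C(C(=O)OC)C1c1ccccc1Cl` gives 25.1 nM in a functional assay (aorta) with Rattus norvegicus as the target; a lower number here means a stronger inhibitor, a higher number a weaker inhibitor. Compound 2 `CCO/C(O)=C1\C(COCCn2ccnn2)=NC(C)=C(C(=O)OC)C1c1cccc(Cl)c1Cl` gives 5.01 nM in this assay, and compound 3 `CCO/C(O)=C1\C(COCCN2CC(=O)N(C)C2=O)=NC(C)=C(C(=O)OC)C1c1cccc(Cl)c1Cl` gives 5.01 nM. Compound 1 therefore stands highest of the three values, with both other compounds beyond the scatter below it. Within the data shown here, the only step between measured compounds that differ in one place, no change at the digits printed from compound 2 to compound 3 (within the scatter), exchanges one group for another on a saturated chain carbon, two bonds along the chain from an oxygen on a saturated carbon, and shows no movement at all.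

Compound 4 `CCO/C(O)=C1\C(COCCn2ccnc2C)=NC(C)=C(C(=O)OC)C1c1ccccc1Cl` has not yet been measured. It differs from compound 1 by a group of 6 heavy atoms (4 carbon, 2 nitrogen; one five-membered aromatic ring with 2 hetero atoms) in place of a group of 8 heavy atoms (4 carbon, 3 nitrogen, 1 oxygen; one five-membered aromatic ring with 2 hetero atoms), on a saturated chain carbon, two bonds along the chain from an oxygen on a saturated carbon. Among the measured compounds shown here, the measured step bears on this change in that it also exchanges the group at that same place and came out flat within the scatter; no measured step, however, starts from compound 1 itself, and the two measured partners carry a different halogen pattern on their aryl ring. The expectation is accordingly a step of about a 1.0-fold lower number from compound 1 to compound 4 (0.00 log units; within the scatter), that is, none beyond the scatter. Compound 4 is estimated to give 25 nM in this assay, with a range from 8 nM to 80 nM.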

Compound 4, half-maximal inhibitory concentration: 2.51 nM
For compound 4 the middle estimate is 10-fold (1.00 log units) above the measured one, and the stated range ends above it.
By their numbers in this assay, from the lowest: compounds 4, 2 and 3 (each within the scatter of the next); then compound 1.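

Among these compounds, at the saturated chain carbon, two bonds along the chain from an oxygen on a saturated carbon, the group proves not to be indifferent in this assay: the only earlier step at this place was flat, with no change at the digits printed from compound 2 to compound 3 (within the scatter), whereas 2-methyl-1H-imidazol-1-yl in place of the larger group gives a 10-fold lower number from compound 1 to compound 4 (1.00 log units; beyond the scatter). Among the compounds shown here, this is also the first step at this place read on the aryl ring shared by compound 1 and compound 4, whose halogen pattern differs from that of compound 2 and compound 3. The exchange replaces a group of 8 heavy atoms with 1 hydrogen-bond donor by one of 6 heavy atoms with 0 hydrogen-bond donors, and nothing measured here shows which of these differences, if either, accounts for the step.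

The compounds shown leave open whether the methyl group of the 2-methyl-1H-imidazol-1-yl contributes to the step, which a plain 1H-imidazol-1-yl at the same place would test. They also leave open whether a simple amine such as dimethylamino at this place would behave like the ring groups, and whether the exchange gives the same step on the aryl ring of compound 2.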